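Swapping a flexible chain for a rigid aryl arm

A few compounds are considered here, and "the series" means these few. Any claim that something is new, unique, unknown or untested is made for them only; others in the source may bear on it.

Three compounds share one core and differ only in the arm carried on a saturated chain carbon bound to an amine nitrogen. Compound 1, with structure `c1ccc2c(c1)CN[C@@H](CN(CCCCNCc1ccncc1)[C@H]1CCCc3cccnc31)C2`, gives 22.7 nM in a functional assay on cells for antagonist activity at C-X-C chemokine receptor type 4 (Homo sapiens), read by fluorescence and calcium flux, with stated times of 25 min and 90 s; on this read-out lower numbers stand for stronger inhibition and higher numbers for weaker inhibition. Compound 2, with structure `c1ccc2c(c1)CN[C@@H](CN(CCCCNCC1CCSCC1)[C@H]1CCCc3cccnc31)C2`, gives 69.6 nM. Compound 3, with structure `c1ccc2c(c1)CN[C@@H](CN(CCCCNC1CCOCC1)[C@H]1CCCc3cccnc31)C2`, gives 29.4 nM, the second highest of the three numbers; its gap to compound 1 lies within the scatter, while the step of a 2.4-fold lower number from compound 2 to compound 3 (0.37 log units; beyond the scatter) lies beyond it, as does a 3.1-fold higher number from compound 1 to compound 2 (0.49 log units; beyond the scatter). The step of a 1.3-fold higher number from compound 1 to compound 3 (0.11 log units; within the scatter) shows that trading a pyridinylmethyl for an oxanyl barely matters.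

Compound 4, with structure `NCc1ccccc1CN(C[C@H]1Cc2ccccc2CN1)[C@H]1CCCc2cccnc21`, is not yet measured. The change is 2-(aminomethyl)phenyl in place of 3-((oxan-4-yl)amino)propyl on a saturated chain carbon bound to an amine nitrogen. Every measured step kept the four-carbon chain and its distal amine and only varied the group on that amine; none of them removed the chain itself, so none bears directly on this change. As far as these compounds go, the three measured numbers sit close together, which suggests the core tolerates varied arms, but a shorter, rigid arm is untested ground. A modest weakening is expected, with wide uncertainty: the step of a 2.0-fold higher number from compound 3 to compound 4 (0.31 log units; beyond the scatter) is the estimate, giving compound 4 an expected 60 nM, within 15 nM to 250 nM.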

Compound 4, half-maximal inhibitory concentration: 50.8 nM
Compound 4: the middle estimate sits 1.2-fold (0.07 log units) above what was measured; measured number inside the range.
By their numbers in this assay, from the lowest: compounds 1, 3, 4 and 2 (each within the scatter of the next, the first and the last beyond it).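

Going by these compounds alone, compound 4 is the first here whose arm at this place, on a saturated chain carbon bound to an amine nitrogen, is built on a six-membered aromatic ring of carbon only, and in this assay the position still accepts it: the step of a 1.7-fold higher number from compound 3 to compound 4 (0.24 log units; within the scatter) and the step of a 1.4-fold lower number from compound 2 to compound 4 (0.14 log units; within the scatter) leave the new arm indistinguishable from the two saturated-ring arms. Only the comparison with the pyridine-bearing arm separates the new arm from an earlier one, in the modest step of a 2.2-fold higher number from compound 1 to compound 4 (0.35 log units; beyond the scatter). Nothing measured here explains why such different arms give such similar numbers, so the reason remains unknown.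

As far as these compounds go, it remains open how much the amine of the 2-(aminomethyl)phenyl arm contributes, which a plain phenyl arm or a carboxylic acid in place of the aminomethyl group could help to show. Also open, from the compounds shown here alone, is whether a longer chain joining the benzene ring to that amine would bring the number closer to that of compound 1, or whether a pyridine ring in place of the benzene ring would do so.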